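Working notes: trifluoromethyl in place of ethyl

A few compounds are considered here, and "the series" means these few. Any claim that something is new, unique, unknown or untested is made for them only; others in the source may bear on it.

Measured so far in a functional assay on MCF7 cells (Homo sapiens) for antiproliferative activity, with a stated time of 5 days (a higher number here means a weaker inhibitor, a lower number a stronger inhibitor), on the shared core:
- compound 1 `CCCCc1ccc2[nH]c(-c3ccc(C)cc3)c(C=C(C#N)C#N)c2c1` gives 100 nM
- compound 2 `CCCCc1ccc2[nH]c(-c3ccc(CC)cc3)c(C=C(C#N)C#N)c2c1` gives 200 nM

Compound 2 has only compound 1 for comparison, and the two values lie within the scatter of each other. The next compound, compound 3 `CCCCc1ccc2[nH]c(-c3ccc(C(F)(F)F)cc3)c(C=C(C#N)C#N)c2c1`, carries trifluoromethyl in place of ethyl on an aromatic carbon. Among the compounds with values here, one measured step bears on this substituent (a 2.0-fold higher number from compound 1 to compound 2 (0.30 log units; within the scatter)), and it lies within the scatter. Within the data shown here, that step adds a single chain carbon, whereas trifluoromethyl brings in fluorine, which no measured compound holds. The data therefore show no direction for this change, and the range has to stay wide. In this assay no step beyond the scatter is expected, and the estimated move is small (a 1.3-fold lower number from compound 2 to compound 3 (0.12 log units; within the scatter)). For compound 3 the estimated value is 150 nM (expected range 50 nM to 500 nM).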

Compound 3, half-maximal inhibitory concentration: 150 nM
Estimate against measurement, compound 3: no gap at the digits printed, within the range that was stated.
By their numbers in this assay, from the lowest: compounds 1, 3 and 2 (each within the scatter of the next).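

In this assay, trifluoromethyl on this aromatic carbon, para to a large group, brings the first fluorine into the series, and the replacement of ethyl gives a 1.3-fold lower number from compound 2 to compound 3 (0.12 log units; within the scatter). Against the smaller methyl, the same group gives a 1.5-fold higher number from compound 1 to compound 3 (0.18 log units; within the scatter). Methyl, ethyl and trifluoromethyl therefore stand within the scatter of one another, so the earlier reading from a single added chain carbon now extends to a group with four heavy atoms in place of two, and to a change of element, with no separation between the three compounds in this assay. No measurement to hand bears on why these three compounds read alike.

Still open is how this aromatic carbon responds to groups of another kind, such as an amine, a carboxylic acid or a longer chain, since all three groups shown carry no hydrogen-bond donors, no hydrogen-bond acceptors and no net charge. The butyl chain and the two nitrile groups are the same in all three compounds, so the data shown say nothing about changes at those places.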